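A few compounds are considered here, and "the series" means these few. Any claim that something is new, unique, unknown or untested is made for them only; others in the source may bear on it.

In a functional assay (aorta) with Oryctolagus cuniculus as the target (on this read-out lower numbers stand for tighter binding and higher numbers for weaker binding), compound 1 `CC(=O)Nc1ccc(OCCCN2CCC(C(c3ccc(F)cc3)c3ccc(F)cc3)CC2)cc1` gives 12.6 nM and compound 2 `Fc1ccc(C(c2ccc(F)cc2)C2CCN(CCCOc3cccc4ccccc34)CC2)cc1` gives 5.01 nM as the lower of the two numbers. Compound 3 `Fc1ccc(C(c2ccc(F)cc2)C2CCN(CCCSc3ccccc3)CC2)cc1` carries phenylsulfanyl in place of (naphthalen-1-yl)oxy on a saturated chain carbon (phenylsulfanyl in place of (naphthalen-1-yl)oxy on a saturated chain carbon, three bonds along the chain from an amine nitrogen in a ring). Within the data shown here, the one measured step that bears on this also swaps a group on that chain. It shows a 2.5-fold lower number from compound 1 to compound 2 (0.40 log units; beyond the scatter) for that swap. Among the measured compounds shown here, no measurement yet isolates either part of the new change, so in this assay a step of similar modest size toward a higher number is expected, estimated as a 2.4-fold higher number from compound 2 to compound 3 (0.38 log units; beyond the scatter) here. For compound 3 the expected value is 12 nM with 4 nM to 36 nM as the estimated range.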

Compound 3, dissociation constant: 3.16 nM
The estimate for compound 3 lay 3.8-fold (0.58 log units) above the measured number; measured number outside the range, below it.
By their numbers in this assay, from the lowest: compounds 3 and 2 (each within the scatter of the next); then compound 1.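

In this assay the swap to phenylsulfanyl, with its single aromatic ring and sulfur, gives a 1.6-fold lower number from compound 2 to compound 3 (0.20 log units; within the scatter) and so shows no change beyond the usual scatter. This place on the chain therefore tolerates the loss of the second aromatic ring of (naphthalen-1-yl)oxy, while a 4.0-fold lower number from compound 1 to compound 3 (0.60 log units; beyond the scatter) shows that compound 3 also keeps a clear edge over the 4-acetamidophenoxy group. Nothing measured here explains this result. As far as these compounds go, because sulfur and ring size change together, their separate contributions remain open, and phenoxy at this place would help separate them.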